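Ester side chain kept, a chloro swap on the distal ring

The source may report more compounds than this note shows. Statements on the series, on what has been measured and on what is new or still open speak of the compounds shown alone.

Both compounds examined here carry a shared core with an amide and a long chain ending in a carboxylic acid or its ethyl ester. Compound 1 `CC(C)N(Cc1cccc(OCCCCCC(=O)O)c1)C(=O)c1ccc(-c2cccc(Oc3ccccc3)c2)cc1` was tested in an ADME assay on Raji cells (Homo sapiens) for cytotoxicity, read by CellTiter-Glo and resazurin assay, with a stated time of 72 h; a lower number here means that less compound is needed, a higher number that more compound is needed for the effect. Compound 1 reached only a limit of the assay, > 18700 nM, as the limit of > 18700 nM in this assay, at which 1 of the 2 values shown sits, notes. Compound 2 `CCOC(=O)CCCCCOc1cccc(CN(C(=O)c2ccc(-c3cccc(OCC(C)C)c3)cc2)C(C)C)c1` likewise gave only a limit in this assay, > 26000 nM, which is where the limit of > 26000 nM in this assay, at which 1 of the 2 values shown sits, places it. So compound 2 stands at the top of what this assay can report, with no measured number of its own, and the same is true of compound 1.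

Compound 3 `CCOC(=O)CCCCCOc1cccc(CN(C(=O)c2ccc(-c3cccc(Cl)c3)cc2)C(C)C)c1` differs from compound 2 in one place: chloro in place of isobutoxy on an aromatic carbon. Going by the values given here, no measured step in this assay accompanies such a change, and with compound 2 already beyond the measurable range, no shift beyond the scatter is expected. The step from compound 2 to compound 3 is estimated as a step that the limit leaves unreadable from compound 2 to compound 3. Compound 3 is therefore expected to give about 30000 nM, within a range of 10000 nM to 100000 nM, most likely again reported only as a limit.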

Compound 3, half-maximal effective concentration: > 18400 nM
Compound 3: a limit, no number (the forecaster's own chance of this, stated with the estimate: 80%); the middle value is on the limit's open side.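

Going by these compounds alone, compound 2 and compound 3 each gave only a limit, not a number, so no step between them can be read. The compounds shown leave open whether chloro in place of isobutoxy changes the concentration needed for the effect at all.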